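This account rests on a few compounds, and the source may have more. Where it says the series, first, only, none or still open, it means among the compounds named here.

For the measured compounds named here, compound 2 `NC(=O)c1c(NC(=O)c2ccccc2I)sc2c1CCN(C(=S)Nc1ccccc1Cl)C2` is one of two compounds measured so far on a shared core. In a functional assay on MKN-74 cells (Homo sapiens) for antiproliferative activity, with a stated time of 24 h (on this read-out lower numbers stand for stronger inhibition and higher numbers for weaker inhibition), compound 2 gives 17500 nM, the higher of the two numbers. Its only comparator, compound 1 `NC(=O)c1c(NC(=O)c2ccccc2F)sc2c1CCN(C(=S)Nc1ccccc1Cl)C2`, gives in this assay 11100 nM. Going by the values given here, the one measured step between them, iodo in place of fluoro on an aromatic carbon, reads a 1.6-fold higher number from compound 1 to compound 2 (0.20 log units; within the scatter) and so lies within the scatter. Compound 3 `NC(=O)c1c(NC(=O)c2ccccc2C(F)(F)F)sc2c1CCN(C(=S)Nc1ccccc1Cl)C2` differs from compound 2 by trifluoromethyl in place of iodo on an aromatic carbon. Among the compounds with values here, the sole step that bears on this change is that exchange at the same aromatic carbon from compound 1 to compound 2, and it did not move the number beyond the scatter; a further exchange at that carbon is therefore expected to produce no step beyond the scatter, a 1.3-fold lower number from compound 2 to compound 3 (0.10 log units; within the scatter). Compound 3 is estimated to give 14000 nM in this assay, with a range from 6000 nM to 35000 nM.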

Compound 3, half-maximal inhibitory concentration: 21900 nM
The estimate for compound 3 lay 1.6-fold (0.19 log units) below the measured number, and the stated range covers the measured number.
By their numbers in this assay, from the lowest: compounds 1, 2 and 3 (each within the scatter of the next).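

In this assay, trifluoromethyl on this aromatic carbon gives a 1.3-fold higher number from compound 2 to compound 3 (0.10 log units; within the scatter), and set against the fluoro group it gives a 2.0-fold higher number from compound 1 to compound 3 (0.30 log units; within the scatter). All three groups now seen at this place, including one of four heavy atoms in place of a single iodine, therefore stand within the scatter of one another, so the exchanges shown at this carbon have not yet moved the number beyond the scatter. Nothing available beyond these numbers bears on this result.

From the compounds shown here alone, it remains open whether an amine, a carboxylic acid or a longer chain on this carbon would produce a step beyond the scatter. Going by these compounds, it is also open whether an exchange elsewhere on the shared core would move the number further than any exchange seen here.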